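A few compounds are considered here, and "the series" means these few. Any claim that something is new, unique, unknown or untested is made for them only; others in the source may bear on it.

Measured compounds in an assay on isolated protein for inhibition of ubiquitin carboxyl-terminal hydrolase 7 (Homo sapiens), read by fluorescence, with stated times of 30 min and 1 h; on this read-out lower numbers stand for stronger inhibition and higher numbers for weaker inhibition:
- compound 1, `O=C([C@H]1Cc2cc(Cl)cc(-c3ccnc4ccsc34)c2O1)N1CCNCC1`: 90 nM
- compound 2, `O=C(C1Cc2cc(Cl)cc(-c3ccnc4[nH]ccc34)c2O1)N1CCNCC1`: 930 nM

Within the data shown here, compound 2 stands at the higher of the two numbers; compound 1 is the only neighbour, and its lower number lies beyond the scatter, though the two compounds differ in more than one place, so nothing is said here about the origin of that gap.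

Compound 3, `O=C([C@H]1Cc2cc(Cl)cc(-c3ccnc4[nH]ccc34)c2O1)N1CCNCC1`, is the next compound to be measured. Its relation to compound 2 is this: the two compounds have the same atoms and bonds; at least one stereo element is drawn with a configuration in one of them and without one in the other: 1 of 1 stereo elements differ; a stereocentre at a saturated ring carbon is drawn without a configuration in compound 2 and R in compound 3. In words, the two compounds have the same atoms and bonds; the only stereocentre, at a saturated ring carbon, is drawn without a configuration in compound 2 and R in compound 3. Compound 1, which also carries the R configuration at that centre, is the lower of the two numbers.

Taking compound 2 as a mixture of both configurations, compound 3 is expected to sit at a somewhat lower number, a step of a 1.9-fold lower number from compound 2 to compound 3 (0.27 log units; within the scatter), at the edge of the scatter, with the risk that the R form is the weaker one. The estimate for compound 3 in this assay is 500 nM, within 150 nM to 1800 nM.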

Compound 3, half-maximal inhibitory concentration: 450 nM
Estimate against measurement, compound 3: 1.1-fold (0.05 log units) above; the range from low to high includes it.
By their numbers in this assay, from the lowest: compound 1; then compound 3; then compound 2.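

In this assay, drawing the saturated ring carbon as R goes with a 2.1-fold lower number from compound 2 to compound 3 (0.32 log units; beyond the scatter), a modest change, and the only structural difference to which it can be tied is the drawn configuration: the fact that one of compounds 2 and 3 is drawn with a defined configuration and the other without, at the place where they differ. Among these compounds, with the R configuration now on both sides, the exchange on the aromatic carbon can be read on its own for the first time: the group of 9 heavy atoms with 2 nitrogen, in place of the group of 9 heavy atoms with 1 nitrogen and 1 sulfur, goes with a 5.0-fold higher number from compound 1 to compound 3 (0.70 log units; beyond the scatter). Both steps lie beyond the scatter, so the gap first seen between compound 1 and compound 2, which differ in more than one place, now resolves into a part at the stereocentre and a part at the aromatic group.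

The compounds shown leave open how the S configuration at this centre reads in this assay, since no compound here carries it. They also leave open whether an oxygen atom in place of the sulfur of compound 1 would stay near compound 1 or compound 3, and what lies behind the difference between the two aromatic groups.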